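Swapping the aryl ether substituent: permeability expected to hold

The source may report more compounds than this note shows. Statements on the series, on what has been measured and on what is new or still open speak of the compounds shown alone.

Of the compounds shown here, three sharing one core have been measured in an ADME assay for permeability, using PAMPA, with a stated time of 30 min, at pH 7.4; a lower number here means that the compound crosses the layer more slowly, a higher number that the compound crosses the layer faster. Compound 1 `COc1ccc(F)cc1CNCCCNc1ccnc2cc(-c3ccccc3)ccc12` gives 237 10^-6 cm/s. Compound 2 `COc1ccc(F)cc1CNCCCNc1ccnc2cc(-c3cccc4ccccc34)ccc12` gives 237 10^-6 cm/s. Compound 3 `COc1ccc(F)cc1CNCCCNc1ccnc2cc(Oc3ccc(F)cc3)ccc12` gives 317 10^-6 cm/s. On these numbers compound 3 does not stand apart: the steps of a 1.3-fold higher number from compound 1 to compound 3 (0.13 log units; within the scatter) and a 1.3-fold higher number from compound 2 to compound 3 (0.13 log units; within the scatter) both fall within the scatter, as does no change at the digits printed from compound 1 to compound 2 (within the scatter), so the three values read as one level.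

Compound 4 `COc1ccc(F)cc1CNCCCNc1ccnc2cc(Oc3cccc(N(C)C)c3)ccc12` has not been measured. It differs from compound 3 in one place: 3-(dimethylamino)phenyl in place of 4-fluorophenyl on an oxygen on an aromatic ring. The measured steps that bear on it are those into compound 3, where a whole group hanging on the aromatic carbon of the shared core was exchanged, a 1.3-fold higher number from compound 1 to compound 3 (0.13 log units; within the scatter) and a 1.3-fold higher number from compound 2 to compound 3 (0.13 log units; within the scatter), neither beyond the scatter. Among the compounds with values here, the new step alters only the outer ring of that group, and no measured pair shows such an exchange, so the closest guidance is that larger exchanges at this place left the read-out unchanged. Compound 4 is therefore expected to show no step beyond the scatter in this assay, that is a 1.1-fold lower number from compound 3 to compound 4 (0.05 log units; within the scatter). Compound 4 is estimated at 280 10^-6 cm/s, with a range from 170 10^-6 cm/s to 450 10^-6 cm/s.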

Compound 4, apparent permeability: 317 10^-6 cm/s
For compound 4 the middle estimate is 1.1-fold (0.05 log units) below the measured one, and the stated range covers the measured number.
By their numbers in this assay, from the lowest: compounds 1, 2, 3 and 4 (each within the scatter of the next).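

Within the data shown here, compound 4 is the first case here in which only the outer ring of the ether group is exchanged while the oxygen stays in place, and in this assay putting 3-(dimethylamino)phenyl in place of 4-fluorophenyl gives (no change at the digits printed from compound 3 to compound 4 (within the scatter)). So a group carrying a nitrogen can stand where a ring carrying a fluorine stood without the number moving beyond the scatter, and the whole 3-(dimethylamino)phenoxy group also fits with the groups on the aromatic carbon of the shared core (a 1.3-fold higher number from compound 2 to compound 4 (0.13 log units; within the scatter); a 1.3-fold higher number from compound 1 to compound 4 (0.13 log units; within the scatter)), which leaves all four compounds at one level in this assay. Nothing given here explains why this read-out stays level across these exchanges.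

Going by these compounds, all four groups at this place are built on aromatic rings of carbon only and carry no net charge, so it remains open whether the level would hold with a carboxylic acid on the outer ring or with a saturated ring such as piperidine in its place. The rest of the molecule is the same in all four compounds, so these results say nothing about exchanges made elsewhere on it.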